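Replacing an aminomethyl linker with a hydroxycyclohexyl ether

The source may report more compounds than this note shows. Statements on the series, on what has been measured and on what is new or still open speak of the compounds shown alone.

Going by the values given here, compound 3 `FC(F)(F)c1c(-c2ccc(CNC3CCOCC3)c(Cl)c2)ccn2c(CC3CC3)nnc12` gives 54 nM in an assay on cells for binding affinity to metabotropic glutamate receptor 2 (Homo sapiens), read by scintillation proximity assay (on this read-out higher numbers stand for weaker binding and lower numbers for tighter binding), the highest of the three numbers measured so far. Compound 1 `FC(F)(F)c1c(-c2ccc(OC3CCOCC3)c(Cl)c2)ccn2c(CC3CC3)nnc12` gives 12.3 nM in this assay, and compound 2 `FC(F)(F)c1c(-c2ccc(NC3CCOCC3)c(Cl)c2)ccn2c(CC3CC3)nnc12` gives 3.8 nM, so that a 4.4-fold higher number from compound 1 to compound 3 (0.64 log units; beyond the scatter) and a 14-fold higher number from compound 2 to compound 3 (1.15 log units; beyond the scatter). Compound 4 `O[C@H]1CC[C@H](Oc2ccc(-c3ccn4c(CC5CC5)nnc4c3C(F)(F)F)cc2Cl)CC1` differs from compound 3 by (4-hydroxycyclohexyl)oxy in place of ((oxan-4-yl)amino)methyl on an aromatic carbon. This change returns an oxygen link to the aromatic carbon, as in compound 1, so the step of a 4.4-fold higher number from compound 1 to compound 3 (0.64 log units; beyond the scatter) bears most directly on it, whereas a 3.2-fold lower number from compound 1 to compound 2 (0.51 log units; beyond the scatter) concerns the amino linker alone. Among the compounds with values here, compound 4 is therefore expected to give a modestly lower number than compound 3, a 3.6-fold lower number from compound 3 to compound 4 (0.56 log units; beyond the scatter), with no measured pair weighing the exchange of one ring for the other. The estimate for compound 4 is 15 nM, between 5 nM and 45 nM.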

Compound 4, dissociation constant: 3 nM
Beside the measured number, compound 4's estimate is 5.0-fold (0.70 log units) above it, outside the stated range (below it).
By their numbers in this assay, from the lowest: compounds 4 and 2 (each within the scatter of the next); then compound 1; then compound 3.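

In this assay, (4-hydroxycyclohexyl)oxy on this aromatic carbon far outdoes ((oxan-4-yl)amino)methyl (an 18-fold lower number from compound 3 to compound 4 (1.26 log units; beyond the scatter)), and with the oxygen link kept, 4-hydroxycyclohexyl also improves on oxan-4-yl (a 4.1-fold lower number from compound 1 to compound 4 (0.61 log units; beyond the scatter)). The oxygen-linked compound 4 thereby matches the amino-linked compound 2 (a 1.3-fold lower number from compound 2 to compound 4 (0.10 log units; within the scatter)), so the amino link is not needed for a number this low. Nothing shown accounts for these steps.

From the compounds shown here alone, it remains open whether the hydroxyl or the all-carbon ring carries the gain. A plain cyclohexyl ether, a methoxycyclohexyl ether or the opposite stereoisomer would help to separate these.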